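The compounds below may be only part of what the source reports. "The series", "measured", "known", "first", "only" and "open" are said of these compounds alone.

Measured in an assay on membranes from uterus for displacement of a labelled ligand from Angiotensin type II receptor (Sus scrofa), with a stated time of 1.5 h; a lower number here means a stronger inhibitor, a higher number a weaker inhibitor: compound 1 `CCCCOC(=O)NS(=O)(=O)c1sc(CC(C)C)cc1-c1ccc(Cn2cccn2)cc1` gives 2.3 nM; compound 2 `CCCCOC(=O)NS(=O)(=O)c1sc(CC(C)C)cc1-c1ccc(CN2CCN(C)C2=O)cc1` gives 16.5 nM; compound 3 `CCCCOC(=O)NS(=O)(=O)c1sc(CC(C)C)cc1-c1ccc(C(=O)c2ncco2)cc1` gives 13.8 nM.

In this assay compound 3 stands second highest of the three numbers, with compound 2 nearest (a 1.2-fold lower number from compound 2 to compound 3 (0.08 log units; within the scatter)) and compound 1 furthest (a 6.0-fold higher number from compound 1 to compound 3 (0.78 log units; beyond the scatter)). Compound 4 `CCCCOC(=O)NS(=O)(=O)c1sc(CC(C)C)cc1-c1ccc(CN2C(=O)CCC2=O)cc1` differs from compound 3 by (2,5-dioxopyrrolidin-1-yl)methyl in place of (1,3-oxazol-2-yl)carbonyl on an aromatic carbon. Within the data shown here, the steps that bear on this change are a 6.0-fold higher number from compound 1 to compound 3 (0.78 log units; beyond the scatter) and a 7.2-fold higher number from compound 1 to compound 2 (0.86 log units; beyond the scatter), both leaving the (1H-pyrazol-1-yl)methyl of compound 1 for another substituent at the same place, and a 1.2-fold lower number from compound 2 to compound 3 (0.08 log units; within the scatter), which shows two such substituents level. Compound 4, like compound 2, attaches its ring through a methyl link. The step is therefore expected to stay within the scatter: a 1.3-fold higher number from compound 3 to compound 4 (0.12 log units; within the scatter). Compound 4 is estimated at 18 nM, with a range from 7 nM to 45 nM.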

Compound 4, inhibition constant: > 10000 nM
Compound 4: no number, only a limit; the forecaster's own chance of this, stated with the estimate: 2%; at least 550-fold (2.74 log units) between middle value and limit.
By their numbers in this assay, from the lowest: compound 1; then compounds 3 and 2 (each within the scatter of the next). At a limit, above all of these: compound 4.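

Compound 4 gives no number, only a limit: the limit of > 10000 nM in this assay, at which 1 of the 4 values shown sits. The earlier steps shown here at this position were modest at most, whereas on the same methyl link the 2,5-dioxopyrrolidin-1-yl ring gives an at least 600-fold higher number from compound 2 to compound 4 (2.78 log units; beyond the scatter) and an at least 4300-fold higher number from compound 1 to compound 4 (3.63 log units; beyond the scatter), so this position does not accept every five-membered ring on that link. Leaving the (1,3-oxazol-2-yl)carbonyl gives an at least 720-fold higher number from compound 3 to compound 4 (2.86 log units; beyond the scatter). The compounds shown leave open whether pyrrolidin-2-one, with a single ring carbonyl, or a simple amine on the same methyl link would return the number to the range of compound 2.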